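Working notes: extending the aromatic oxygen in a flat series

This account rests on a few compounds, and the source may have more. Where it says the series, first, only, none or still open, it means among the compounds named here.

Compound 1 `CC(C)=CCC1Cc2c(O)cc(=O)n(CCCO)c2CC1(C)C`, compound 2 `CC(C)=CCC/C(C)=C/CC1Cc2c(O)cc(=O)n(CCCO)c2CC1(C)C` and compound 3 `CC(C)=CCC1Cc2c(OC(=O)Nc3ccc(F)cc3)cc(=O)n(CCCO)c2CC1(C)C` share one core. In a functional assay on PANC-1 cells (Homo sapiens) for inhibition, read by MTT assay, with a stated time of 24 h, tested at 10 uM (a lower number here means less inhibition, a higher number more inhibition at the concentration tested (going by the name of the read-out)), compound 1 gives 0%, compound 2 gives 0% and compound 3 gives 0%, so compound 2 stands level with both, with nothing to separate the three. The two measured steps are no change at the digits printed from compound 1 to compound 2 (within the scatter) and no change at the digits printed from compound 1 to compound 3 (within the scatter). Compound 4 `CC(C)=CCC/C(C)=C/CC1Cc2c(OCCCNC(=O)c3ccco3)cc(=O)n(CCCO)c2CC1(C)C` differs from compound 2 by 3-(((furan-2-yl)carbonyl)amino)propyl in place of hydrogen on an oxygen on an aromatic ring. The step that bears on this change is the earlier substitution on the same oxygen, no change at the digits printed from compound 1 to compound 3 (within the scatter), which was flat, as was no change at the digits printed from compound 1 to compound 2 (within the scatter). Among the measured compounds shown here, since no measured step in this assay moves beyond the scatter, the expected step is a number 3 percentage points higher from compound 2 to compound 4 (within the scatter), none beyond the scatter. Compound 4 is estimated at 3% in this assay, within a range from 0% to 15%.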

Compound 4, a percentage reported as inhibition, at one concentration (the size of the read-out at that concentration, not a potency): 2.8%
Beside the measured number, compound 4's estimate is 0.2 percentage points above it; measured number inside the range.
By their numbers in this assay, from the lowest: compounds 1, 2, 3 and 4 (each within the scatter of the next).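

On the aromatic oxygen, 3-(((furan-2-yl)carbonyl)amino)propyl in place of hydrogen gives a number 2.8 percentage points higher from compound 2 to compound 4 (within the scatter) in this assay. This position therefore stays flat with an amide-bearing ether chain as well as with (4-fluorophenyl)carbamoyl, and the reading holds on the longer side chain of the shared core. Nothing available explains this flat reading. Still open, on these data alone, is whether a primary amine or a carboxylic acid at the end of the propyl chain, or a longer chain on this oxygen, would give a step beyond the scatter.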